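From Iodo to Hydroxy on the Aromatic Ring

The compounds below may be only part of what the source reports. "The series", "measured", "known", "first", "only" and "open" are said of these compounds alone.

- Compound 1 `Cc1nc2c(s1)C(=O)C=C(Nc1ccc(Br)cc1)C2=O`: 0.28 ug/mL
- Compound 2 `Cc1nc2c(s1)C(=O)C=C(Nc1ccc(I)cc1)C2=O`: 0.24 ug/mL

In a functional assay on HL-60 cells (Homo sapiens) for inhibition (a lower number here means a stronger inhibitor, a higher number a weaker inhibitor), compound 2 gives 0.24 ug/mL, and this cannot be told apart from compound 1 at 0.28 ug/mL. Next comes compound 3 `Cc1nc2c(s1)C(=O)C=C(Nc1ccc(O)cc1)C2=O`, where the change is hydroxy in place of iodo on an aromatic carbon. Within the data shown here, only one measured step bears on this: a 1.2-fold lower number from compound 1 to compound 2 (0.07 log units; within the scatter). Among the measured compounds shown here, that step stays within the scatter, but it exchanges bromo for iodo, and no measured compound here carries hydroxy. It therefore gives only weak guidance, so a modest move towards a higher number in this assay is expected, with wide uncertainty. The estimated step is a 2.5-fold higher number from compound 2 to compound 3 (0.40 log units; beyond the scatter). For compound 3 the expected value is 0.6 ug/mL, with an estimated range from 0.2 ug/mL to 2 ug/mL.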

Compound 3, half-maximal inhibitory concentration: 0.26 ug/mL
For compound 3 the middle estimate is 2.3-fold (0.36 log units) above the measured one; the measured number falls inside the stated range.
By their numbers in this assay, from the lowest: compounds 2, 3 and 1 (each within the scatter of the next).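

In this assay, hydroxy in place of iodo gives a 1.1-fold higher number from compound 2 to compound 3 (0.03 log units; within the scatter), and hydroxy in place of bromo gives a 1.1-fold lower number from compound 1 to compound 3 (0.03 log units; within the scatter). The earlier pair compared only two halogens, whereas this change swaps iodo, with 0 hydrogen-bond donors and 0 hydrogen-bond acceptors, for a non-halogen group with 1 of each on the same aromatic carbon, and the three compounds still cannot be told apart. Nothing available explains why these groups read alike at this position.

As far as these compounds go, it remains open whether the same holds for an amine, a carboxylic acid, a methoxy group or a longer chain at this carbon. Also unresolved is how a compound with only hydrogen there would compare with these three.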